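Same Swap on Two Cores: What to Expect

This account rests on a few compounds, and the source may have more. Where it says the series, first, only, none or still open, it means among the compounds named here.

Compound 1 `Cc1cc(C)c2sc(NC(=O)c3ccc([N+](=O)[O-])cc3)nc2c1` and compound 2 `Cc1cc(C)c2sc(NC(=O)c3ccc(C(F)(F)F)cc3)nc2c1` share one core and differ only in trifluoromethyl in place of nitro on an aromatic carbon. In a functional assay on NUGC-3 cells (Homo sapiens) for antiproliferative activity, read by sulforhodamine B assay (on this read-out lower numbers stand for stronger inhibition of growth and higher numbers for weaker inhibition of growth), compound 1 gives 1.32 ug/mL. Compound 2 gives 1.4 ug/mL in this assay, so the step of a 1.1-fold higher number from compound 1 to compound 2 (0.03 log units; within the scatter) is flat. Compound 3 `COc1ccc2sc(NC(=O)c3ccc([N+](=O)[O-])cc3)nc2c1` carries the nitro on another core; how the two cores differ is not broken down here. In this assay compound 3 reaches only a limit, > 10 ug/mL. Compound 4 `COc1ccc2sc(NC(=O)c3ccc(C(F)(F)F)cc3)nc2c1` differs from compound 3 by trifluoromethyl in place of nitro on an aromatic carbon, the same change as before. Because the earlier step of a 1.1-fold higher number from compound 1 to compound 2 (0.03 log units; within the scatter) stayed within the scatter, compound 4 is expected to remain near (the limit of > 10 ug/mL in this assay, at which 1 of the 3 values shown sits). The expected step is a step that the limit leaves unreadable from compound 3 to compound 4. Compound 4 is estimated at 15 ug/mL in this assay, most likely between 6 ug/mL and 40 ug/mL.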

Compound 4, concentration for 50% growth inhibition: > 10 ug/mL
Compound 4 gave a limit, no number; the forecaster's own chance of this, stated with the estimate: 70%; the middle value lies beyond the limit too.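

No step can be read from compound 3 to compound 4, since both give only a limit: the limit of > 10 ug/mL in this assay, at which 2 of the 4 values shown sit.

Going by these compounds, what trifluoromethyl in place of nitro does on the core of compound 3 therefore stays open.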